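A few compounds are considered here, and "the series" means these few. Any claim that something is new, unique, unknown or untested is made for them only; others in the source may bear on it.

Measured compounds:
- compound 1 `Nc1ccc(-c2cc(=O)c3c(N)c(F)c(Br)c(F)c3o2)cc1F`: 160 nM
- compound 2 `CN(C)c1c(F)c(N)c2c(=O)cc(-c3ccc(N)c(F)c3)oc2c1F`: 39 nM
- compound 3 `Nc1ccc(-c2cc(=O)c3c(N)c(F)c(C(=O)O)c(F)c3o2)cc1F`: > 10000 nM

In a functional assay on MCF7 cells (Homo sapiens) for cytotoxicity, read by neutral red uptake, with a stated time of 3 days (on this read-out lower numbers stand for stronger inhibition and higher numbers for weaker inhibition), compound 1 gives 160 nM, the higher of the two numbers recorded; its nearest neighbour is compound 2, with a 4.1-fold lower number from compound 1 to compound 2 (0.61 log units; beyond the scatter). For compound 3 this assay reports only a limit, > 10000 nM, not a number (the limit of > 10000 nM in this assay, at which 1 of the 3 values shown sits).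

Compound 4 `CCCCCC(=O)OCc1c(F)c(N)c2c(=O)cc(-c3ccc(N)c(F)c3)oc2c1F` has not yet been measured in this assay. It differs from compound 1 in one place: ((pentylcarbonyl)oxy)methyl in place of bromo on an aromatic carbon.

Two measured steps start from compound 1 at the same position. Swapping bromo for dimethylamino gave a 4.1-fold lower number from compound 1 to compound 2 (0.61 log units; beyond the scatter), a modest gain. Swapping bromo for carboxy gave an at least 62-fold higher number from compound 1 to compound 3 (1.79 log units; beyond the scatter), a large loss. Among the compounds with values here, the ((pentylcarbonyl)oxy)methyl group resembles neither of these, so no measured step tells directly what to expect; the position clearly tolerates some change but not all. A small step, possibly toward a higher number, is expected: a 1.9-fold higher number from compound 1 to compound 4 (0.27 log units; within the scatter). Compound 4 is therefore estimated at 300 nM, with a range of 60 nM to 3000 nM.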

Compound 4, half-maximal inhibitory concentration: 160 nM
The estimate for compound 4 lay 1.9-fold (0.27 log units) above the measured number; the range from low to high includes it.
By their numbers in this assay, from the lowest: compound 2; then compounds 1 and 4 (each within the scatter of the next). At a limit, above all of these: compound 3.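

In this assay, within the data shown here, a group of 9 heavy atoms, ((pentylcarbonyl)oxy)methyl, can stand in for bromo, a single heavy atom, with no change at the digits printed from compound 1 to compound 4 (within the scatter), so this position accepts a far larger group than the earlier compounds showed. Measured against the other two groups at the same carbon, the new group gives an at least 62-fold lower number from compound 3 to compound 4 (1.79 log units; beyond the scatter), and a 4.1-fold higher number from compound 2 to compound 4 (0.61 log units; beyond the scatter), which shows that the poor result with carboxy does not extend to every group other than bromo, while compound 2 keeps the lowest number. The entry for compound 3 is a limit, not a number: the limit of > 10000 nM in this assay, at which 1 of the 4 values shown sits.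

Still open, on these data alone, is how a shorter or longer acyl chain in the same group would read, and how a hydroxymethyl or a primary amine would compare with dimethylamino at this carbon. The numbers also do not tell why carboxy and ((pentylcarbonyl)oxy)methyl part so widely.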